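Compound 3 to compound 4: a carboxy replacement

A few compounds are considered here, and "the series" means these few. Any claim that something is new, unique, unknown or untested is made for them only; others in the source may bear on it.

Compound 1 `Cc1cc(NC(=O)Nc2ccc(F)cc2)c2ccccc2n1` reads > 25000 nM in an ADME assay on HepG2 cells (Homo sapiens) for cytotoxicity, with a stated time of 72 h (a higher number here means that more compound is needed for the effect, a lower number that less compound is needed), as a limit of the assay, not a number. Compound 2 `Cc1cc(NC(=O)Nc2ccc(C(F)(F)F)cc2)c2ccccc2n1` gives 23000 nM in this assay as a measured number. Compound 3 `Cc1cc(NC(=O)Nc2ccc(SC(F)(F)F)cc2)c2ccccc2n1` gives 20000 nM in the same read-out and stands level with its nearest neighbour, the gap being a 1.2-fold lower number from compound 2 to compound 3 (0.06 log units; within the scatter) and so no real difference.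

Compound 4 `Cc1cc(NC(=O)Nc2ccc(C(=O)O)cc2)c2ccccc2n1` carries carboxy in place of (trifluoromethyl)sulfanyl on an aromatic carbon, para to a large group, counted as carboxy in place of (trifluoromethyl)sulfanyl on an aromatic carbon in full.

Three measured swaps at this carbon bear on the change. Beside the gap already given, they are an at least 1.0-fold lower number from compound 1 to compound 2 (0.03 log units; that floor lies within the scatter) and an at least 1.2-fold lower number from compound 1 to compound 3 (0.09 log units; that floor lies within the scatter) as floors set by a limit. None of them reaches beyond the scatter, though none involves carboxy, so the guide is indirect.

The expected step is a 1.3-fold higher number from compound 3 to compound 4 (0.10 log units; within the scatter) and no step beyond the scatter is anticipated, with a slight lean towards a higher number.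

For compound 4 the estimated value is 25000 nM with an expected range from 13000 nM to 45000 nM in this assay here.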

Compound 4, half-maximal effective concentration: > 25000 nM
Compound 4 gave a limit, no number; the forecaster's own chance of this, stated with the estimate: 60%; the middle value lies on the limit itself.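

In this assay compound 4 gives > 25000 nM, which is a limit of the assay and not a number. Carboxy is the first group at this aromatic carbon counted with a hydrogen-bond donor, yet the change shows no step beyond the scatter, with floors of an at least 1.2-fold higher number from compound 3 to compound 4 (0.09 log units; that floor lies within the scatter) and an at least 1.0-fold higher number from compound 2 to compound 4 (0.03 log units; that floor lies within the scatter); the step from compound 1 to compound 4 cannot be read, since both values are limits. The series thus reaches no readable separation at this position, and the four compounds now crowd the top of the range: the limit of > 25000 nM in this assay, at which 2 of the 4 values shown sit.

Going by these compounds, whether an amine or a longer chain at this carbon would give a number clearly apart from these remains open. Whether carboxy and fluoro differ at all is also unresolved.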